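Aryl Swap on the Ring Nitrogen of Compound 2

The source may report more compounds than this note shows. Statements on the series, on what has been measured and on what is new or still open speak of the compounds shown alone.

In an assay on CHO cells for displacement of a labelled ligand from adenosine receptor A1 (Homo sapiens), read by scintillation counting, with a stated time of 120 min, tested at 10 uM (on this read-out higher numbers stand for more inhibition at the one concentration tested (going by the name of the read-out) and lower numbers for less inhibition), compound 1 `CC(C)N1CCN(Cc2csc(N)c2C(=O)c2ccc(Cl)cc2)CC1` gives 0% and compound 2 `Nc1scc(CN2CCN(c3ccccc3F)CC2)c1C(=O)c1ccc(Cl)cc1` gives 4%. Within the data shown here, the only step so far, a number 4 percentage points higher from compound 1 to compound 2 (within the scatter), came from 2-fluorophenyl in place of isopropyl on an amine nitrogen in a ring. Compound 3 `Nc1scc(CN2CCN(c3cccc(Cl)c3)CC2)c1C(=O)c1ccc(Cl)cc1` differs from compound 2 by 3-chlorophenyl in place of 2-fluorophenyl on an amine nitrogen in a ring. Among the measured compounds shown here, that earlier step is the sole guide, and it stayed within the scatter, so the step of no change at the digits printed from compound 2 to compound 3 (within the scatter) is expected to stay within the scatter as well. Compound 3 is therefore estimated at 4%, between -5% and 15%.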

Compound 3, a percentage reported as inhibition, at one concentration (the size of the read-out at that concentration, not a potency): 0%
The estimate for compound 3 lay 4 percentage points above the measured number; measured number inside the range.
By their numbers in this assay, from the lowest: compounds 1, 3 and 2 (each within the scatter of the next).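

In this assay the 3-chlorophenyl group gives a number 4 percentage points lower from compound 2 to compound 3 (within the scatter) against 2-fluorophenyl and no change at the digits printed from compound 1 to compound 3 (within the scatter) against isopropyl on the amine nitrogen in a ring. A second aryl group, now bearing chlorine rather than fluorine, therefore separates none of the three compounds at this position, so the earlier flat step was not unique to 2-fluorophenyl. Nothing available explains this result. From the compounds shown here alone, whether a benzyl group, an amide or a carboxylic acid on this nitrogen would give a step beyond the scatter remains open.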